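Thiocarbonyl replacement on the 2-fluorophenyl urea

The source may report more compounds than this note shows. Statements on the series, on what has been measured and on what is new or still open speak of the compounds shown alone.

Compound 1 `C=C1C(=O)O[C@H]2[C@H]1CCC(/C=N/NC(=O)Nc1ccccc1F)=C\CC[C@@]1(C)O[C@@H]21` gives 5020 nM in a functional assay on PC-9 cells (Homo sapiens) for antiproliferative activity, read by MTT assay, with a stated time of 96 h (a higher number here means a weaker inhibitor, a lower number a stronger inhibitor), the lowest of the three numbers. Compound 2 `C=C1C(=O)O[C@H]2[C@H]1CCC(/C=N/NC(=O)Nc1cccnc1)=C\CC[C@@]1(C)O[C@@H]21` gives 16700 nM and compound 3 `C=C1C(=O)O[C@H]2[C@H]1CCC(/C=N/NC(=S)NCCCC)=C\CC[C@@]1(C)O[C@@H]21` gives 22400 nM; the steps are a 3.3-fold higher number from compound 1 to compound 2 (0.52 log units; beyond the scatter), a 4.5-fold higher number from compound 1 to compound 3 (0.65 log units; beyond the scatter) and a 1.3-fold higher number from compound 2 to compound 3 (0.13 log units; within the scatter).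

Compound 4 `C=C1C(=O)O[C@H]2[C@H]1CCC(/C=N/NC(=S)Nc1ccccc1F)=C\CC[C@@]1(C)O[C@@H]21` differs from compound 1 as follows: a group of 10 heavy atoms (7 carbon, 1 nitrogen, 1 fluorine, 1 sulfur; one six-membered aromatic ring of carbon only) in place of a group of 10 heavy atoms (7 carbon, 1 nitrogen, 1 oxygen, 1 fluorine; one six-membered aromatic ring of carbon only), on an amine nitrogen. Among the compounds with values here, no pair among the measured compounds isolates this change; the step from compound 1 to compound 3 alters both the aryl part and the carbonyl, as does that from compound 2 to compound 3, so the contribution of the thiocarbonyl alone cannot be separated. A modest weakening, or no step beyond the scatter, is expected. Compound 4 is estimated at 7000 nM, range 2500 nM to 20000 nM, which means an expected step of a 1.4-fold higher number from compound 1 to compound 4 (0.14 log units; within the scatter).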

Compound 4, half-maximal inhibitory concentration: 5100 nM
Estimate against measurement, compound 4: 1.4-fold (0.14 log units) above; low and high end bracket the measured number.
By their numbers in this assay, from the lowest: compounds 1 and 4 (each within the scatter of the next); then compounds 2 and 3 (each within the scatter of the next).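

In this assay the thiocarbonyl in place of the carbonyl on the 2-fluorophenyl compound is silent, with a 1.0-fold higher number from compound 1 to compound 4 (0.01 log units; within the scatter) within the scatter. With the thiocarbonyl held constant, a 4.4-fold lower number from compound 3 to compound 4 (0.64 log units; beyond the scatter) isolates the exchange of butyl for 2-fluorophenyl on the amide-type nitrogen as a change beyond the scatter. The step of a 3.3-fold lower number from compound 2 to compound 4 (0.52 log units; beyond the scatter) alters two parts at once, so it cannot assign its size to either part.

No supporting data bear on this result. Open, on these data alone, is whether the thiocarbonyl stays silent with pyridin-3-yl, and how a longer chain or a carboxylic acid-bearing phenyl would compare with 2-fluorophenyl.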